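Phenyl for allyl on an oxadiazole amine

The source may report more compounds than this note shows. Statements on the series, on what has been measured and on what is new or still open speak of the compounds shown alone.

Of the compounds shown here, three sharing one core have been measured in a functional assay on the whole organism (strain BALB/c) for inhibition, with Mus musculus as the target, read by paw edema, with a stated time of 4 h, at a dose of 50 mg/kg by the oral route; a higher number here means more inhibition at the dose given (going by the name of the read-out), a lower number less inhibition. Compound 1 `Cc1ccc(-n2c(-c3cc(-c4ccc(F)cc4F)ccc3O)n[nH]c2=S)cc1` gives 51.6%, and compound 2 `Cn1c(-c2cc(-c3ccc(F)cc3F)ccc2O)n[nH]c1=S` gives 56.9%. Among the compounds with values here, the one step between these two, a number 5.3 percentage points higher from compound 1 to compound 2 (within the scatter), is within the scatter. Compound 3 `C=CCNc1nnc(-c2cc(-c3ccc(F)cc3F)ccc2O)o1` gives 36.6%, the lowest of the three numbers, with compound 1 the nearest and compound 2 the furthest, both beyond the scatter.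

The new compound 4 `Oc1ccc(-c2ccc(F)cc2F)cc1-c1nnc(Nc2ccccc2)o1` differs from compound 3 in one place: phenyl in place of allyl on a nitrogen on an aromatic ring. Within the data shown here, no measured step has the same change. Among the measured compounds shown here, the only step at hand, the one from compound 1 to compound 2, swaps a methyl for a 4-methylphenyl on an aromatic nitrogen in a different core, and it stays within the scatter, so it offers only a loose parallel for an alkyl-to-aryl exchange on a nitrogen. On that basis a step of a number 3.4 percentage points higher from compound 3 to compound 4 (within the scatter) in this assay is expected, that is no change beyond the scatter. Compound 4 is therefore estimated at 40%, within 25% to 55%.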

Compound 4, a percentage reported as inhibition, in the whole organism at one dose (the size of the read-out at that dose, not a potency): 39.5%
Compound 4: middle estimate off by 0.5 percentage points, on the high side; the range from low to high includes it.
By their numbers in this assay, from the lowest: compounds 3 and 4 (each within the scatter of the next); then compounds 1 and 2 (each within the scatter of the next).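

In this assay the exchange on a nitrogen on an aromatic ring, allylamino to anilino, gives a number 2.9 percentage points higher from compound 3 to compound 4 (within the scatter) and so leaves the two compounds unseparated by this read-out. Within the data shown here, this is the first direct reading at this position, and it shows that allyl, with its double bond outside aromatic rings, and phenyl, with its six-membered aromatic ring of carbon only, are not told apart here at the single dose given. Nothing at hand bears on why the two compounds read alike.

From the compounds shown here alone, whether a benzyl group, a longer chain or a plain methyl on the same nitrogen would read differently remains open. So does whether a chlorine or a methoxy group on the entering phenyl would move the number beyond the scatter.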